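A single ring swap on compound 1

The source may report more compounds than this note shows. Statements on the series, on what has been measured and on what is new or still open speak of the compounds shown alone.

In a physicochemical assay for solubility, measured as kinetic solubility, at pH 2 (a lower number here means a less soluble compound, a higher number a more soluble compound), compound 1 `CC(C)[C@H](C[C@H]1OC(=O)NC1=O)c1ccc(-c2ccc3cccc(F)c3c2)[nH]c1=O` gives 24400 nM, compound 2 `CC(C)C(c1ccc(-c2ccc3cccc(F)c3c2)[nH]c1=O)C1C(=O)NC(=O)N1C` gives 13600 nM and compound 3 `O=C1NC(=O)/C(=C/C(c2ccccc2)c2ccc(-c3ccc4cccc(F)c4c3)[nH]c2=O)O1` gives 15400 nM. Compound 1 therefore stands level with the other two, as all three values lie within the scatter of one another. Compound 4 `CC(C)[C@H](C[C@H]1SC(=O)NC1=O)c1ccc(-c2ccc3cccc(F)c3c2)[nH]c1=O` differs from compound 1 by 2,4-dioxo-1,3-thiazolidin-5-yl in place of 2,4-dioxo-1,3-oxazolidin-5-yl on a saturated chain carbon, two bonds along the chain from an aromatic carbon, with 2,4-dioxo-1,3-thiazolidin-5-yl in place of 2,4-dioxo-1,3-oxazolidin-5-yl on a saturated chain carbon, two bonds along the chain from an aromatic carbon. Among the compounds with values here, no two measured compounds differ in only one place, so no measured step guides this expectation. The expected change is a 1.6-fold lower number from compound 1 to compound 4 (0.21 log units; within the scatter), a modest move toward a lower number that stays within the scatter. For compound 4 the estimated value is 15000 nM, with an expected range of 7000 nM to 28000 nM.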

Compound 4, solubility: 4900 nM
The estimate for compound 4 lay 3.1-fold (0.49 log units) above the measured number, outside the stated range (below it).
By their numbers in this assay, from the lowest: compound 4; then compounds 2, 3 and 1 (each within the scatter of the next).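

Within the data shown here, replacing 2,4-dioxo-1,3-oxazolidin-5-yl with 2,4-dioxo-1,3-thiazolidin-5-yl on a saturated chain carbon, two bonds along the chain from an aromatic carbon, gives in this assay a 5.0-fold lower number from compound 1 to compound 4 (0.70 log units; beyond the scatter), the only readable step here and one beyond the scatter. The two groups match in every printed count except that one oxygen gives way to one sulfur, so this position is not indifferent to that exchange. Nothing measured here explains the drop. On these data alone, whether it would recur on the cores of compound 2 or compound 3 stays open, as does how an amine or a carboxylic acid at this place would read in this assay.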